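Methoxy Addition on a Benzoxaborole Amide Series

The source may report more compounds than this note shows. Statements on the series, on what has been measured and on what is new or still open speak of the compounds shown alone.

Measured so far:
compound 1, `COc1ccc(NC(=O)CCc2cccc3c2B(O)OC3)cc1`: 1700 nM
compound 2, `COc1ccc(NC(=O)CCc2cccc3c2B(O)OC3)cc1OC`: > 100000 nM
compound 3, `COc1cccc(-c2cccc(NC(=O)CCc3cccc4c3COB4O)c2)c1`: 46000 nM

In a functional assay on HCT-116 cells (Homo sapiens) for antiproliferative activity, read by MTT assay, with a stated time of 72 h (a higher number here means a weaker inhibitor, a lower number a stronger inhibitor), compound 1 gives 1700 nM. Compound 2 carries methoxy in place of hydrogen on an aromatic carbon, and in this assay compound 2 reaches only a limit of the assay, > 100000 nM, rather than a number. That step, an at least 58-fold higher number from compound 1 to compound 2 (1.76 log units; beyond the scatter), is set by the limit of > 100000 nM in this assay, at which 1 of the 3 values shown sits. Compound 3 gives 46000 nM in this assay; the difference between the core of compound 3 and the core of compound 1 is not broken down here.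

Compound 4, `COc1cc(OC)cc(-c2cccc(NC(=O)CCc3cccc4c3COB4O)c2)c1`, has not yet been measured. It differs from compound 3 by methoxy in place of hydrogen on an aromatic carbon. This is the same kind of change as that from compound 1 to compound 2, though the surroundings differ: in compound 2 the new methoxy sits ortho to a methoxy group, whereas in compound 4 it sits meta to a methoxy group. Resting on the step from compound 1 to compound 2 in this assay, an at least 58-fold higher number from compound 1 to compound 2 (1.76 log units; beyond the scatter), the step from compound 3 to compound 4 is expected to be a 3.3-fold higher number from compound 3 to compound 4 (0.51 log units; beyond the scatter). Compound 4 is therefore estimated at 150000 nM, between 40000 nM and 600000 nM, with a fair chance that only a limit is reported.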

Compound 4, half-maximal inhibitory concentration: 50000 nM
Compound 4: middle estimate off by 3.0-fold (0.48 log units), on the high side; low and high end bracket the measured number.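

In this assay, the step on the core of compound 3 is a 1.1-fold higher number from compound 3 to compound 4 (0.04 log units; within the scatter), and the same change does not carry over in size from one core to the other: the same change on two cores in this assay, an at least 58-fold higher number (1.76 log units; beyond the scatter) from compound 1 to compound 2 and a 1.1-fold higher number (0.04 log units; within the scatter) from compound 3 to compound 4, at least 54-fold (1.73 log units) apart, beyond the scatter of two such steps. Going by these compounds, compound 2 stands at a limit of the assay and not at a number, so the full size of the earlier step stays unknown: the limit of > 100000 nM in this assay, at which 1 of the 4 values shown sits. Among the compounds shown here, with a single pair on each core, the result shows only that the step on one core did not predict the step on the other, and it does not show whether the core or the place of the added methoxy relative to the existing methoxy group accounts for the gap.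

The aromatic groups shown carry only hydrogen and methoxy at the changed places, so it remains open how an amine, a carboxylic acid or a fluorine there would read. On these data alone, it also remains open whether a longer chain on the amide carbonyl would alter the size of either step.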